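Carboxy to formyl on the benzyloxy arm of a pentylamine ether

A few compounds are considered here, and "the series" means these few. Any claim that something is new, unique, unknown or untested is made for them only; others in the source may bear on it.

Compound 1 `c1ccc(COc2ccc(OCCOCCNC3CCCC3)cc2)cc1` gives 24800 nM in a functional assay on SK-OV-3 cells (Homo sapiens) for inhibition, read by CCK-8 assay, with a stated time of 70 h; on this read-out higher numbers stand for weaker inhibition and lower numbers for stronger inhibition.
Compound 2 `Nc1ccc(COc2ccc(OCCOCCNC3CCCC3)cc2)cc1` gives 31700 nM in this assay.
Compound 3 `O=C(O)c1ccc(COc2ccc(OCCOCCNC3CCCC3)cc2)cc1` reaches only the limit > 100000 nM in this assay, so for it a limit and no number is known.

Of the three measured compounds, compound 3 stands at the weak end on the numbers shown: the step of an at least 4.0-fold higher number from compound 1 to compound 3 (0.60 log units; beyond the scatter) and the step of an at least 3.1-fold higher number from compound 2 to compound 3 (0.49 log units; beyond the scatter) both run beyond the scatter, while a 1.3-fold higher number from compound 1 to compound 2 (0.11 log units; within the scatter) stays within it. Compound 4 `O=Cc1ccc(COc2ccc(OCCOCCNC3CCCC3)cc2)cc1` differs from compound 3 by hydrogen in place of hydroxy on a carbonyl carbon, that is, carboxy becomes formyl on the 4-carboxyphenyl group. Going by the values given here, the steps that bear on this change are the two that put the carboxy in place, from compound 1 and from compound 2, since the change to compound 4 takes away the hydroxy of that carboxy and leaves the carbonyl behind. Among the compounds with values here, because an at least 4.0-fold higher number from compound 1 to compound 3 (0.60 log units; beyond the scatter) is the only measured step in which the carboxy appears against a hydrogen, the expectation is that compound 4 moves part of the way back towards compound 1, giving a lower number than the limit of compound 3, with the step of an at least 2.2-fold lower number from compound 3 to compound 4 (0.34 log units; beyond the scatter) expected. Compound 4 is therefore estimated at 45000 nM, between 15000 nM and 130000 nM.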

Compound 4, half-maximal inhibitory concentration: 45000 nM
Estimate against measurement, compound 4: no gap at the digits printed, and the stated range covers the measured number.
By their numbers in this assay, from the lowest: compounds 1, 2 and 4 (each within the scatter of the next). At a limit, above all of these: compound 3.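

Removing only the hydroxy and keeping the carbonyl gives an at least 2.2-fold lower number from compound 3 to compound 4 (0.34 log units; beyond the scatter) in this assay, so on this arm the weak end of the set goes with the complete carboxy and not with a carbonyl on the aromatic carbon as such. The formyl group cannot be told apart from the groups already measured at this place, with a 1.4-fold higher number from compound 2 to compound 4 (0.15 log units; within the scatter) and a 1.8-fold higher number from compound 1 to compound 4 (0.26 log units; within the scatter) both lying within the scatter, so hydrogen, amino and formyl form one level in this small set, and only the carboxy stands apart from it. That separation has an open upper end, since compound 3 has a limit and no number: the limit of > 100000 nM in this assay, at which 1 of the 4 values shown sits.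

As far as these compounds go, how far compound 3 really lies from the other three therefore stays unknown, and the step to compound 4 gives only a bound on its size. From the compounds shown here alone, it also remains open whether a methyl ester, a primary carboxamide or a hydroxymethyl group on the same aromatic carbon would join the level of hydrogen, amino and formyl or stay with the carboxylic acid.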